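From compound 2 to compound 3: a pyridinyl exchange

This account rests on a few compounds, and the source may have more. Where it says the series, first, only, none or still open, it means among the compounds named here.

In a functional assay on the whole organism with Rattus norvegicus as the target (a higher number here means that more compound is needed for the effect, a lower number that less compound is needed), compound 2 `Cc1cc(C)c(NC(=O)N(Cc2ccc(Oc3ccc(F)cc3)cc2)C2CCCCCC2)c(C)n1` gives 0.044 mg/kg and compound 1 `CSc1nc(C)nc(SC)c1NC(=O)N(Cc1ccc(Oc2ccc(F)cc2)cc1)C1CCCCCC1` gives 0.069 mg/kg, so the two values lie within the scatter of each other. Compound 3 `COc1nc(C)ccc1NC(=O)N(Cc1ccc(Oc2ccc(F)cc2)cc1)C1CCCCCC1` has 2-methoxy-6-methylpyridin-3-yl in place of 2,4,6-trimethylpyridin-3-yl on an amide-type nitrogen. Among the measured compounds shown here, no measured step tests this exchange directly. For the measured compounds named here, the only evidence is a different exchange on the same amide-type nitrogen, a 1.6-fold lower number from compound 1 to compound 2 (0.20 log units; within the scatter). That single step gives no basis for a direction in this assay. The step expected is a 1.1-fold higher number from compound 2 to compound 3 (0.06 log units; within the scatter), with no shift beyond the scatter. Compound 3 is estimated at 0.05 mg/kg, with an expected range of 0.018 mg/kg to 0.15 mg/kg.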

Compound 3, dose for half-maximal effect: > 0.1 mg/kg
Compound 3: a limit, no number; the forecaster's own chance of this, stated with the estimate: 3%; at least 2.0-fold (0.30 log units) between middle value and limit.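

In this assay compound 3 gives > 0.1 mg/kg, which is a limit of the assay and not a number: the limit of > 0.1 mg/kg in this assay, at which 1 of the 3 values shown sits.

Even as a limit it gives a readable result: an at least 2.2-fold higher number from compound 2 to compound 3 (0.35 log units; beyond the scatter). Among the compounds shown here, this makes 2-methoxy-6-methylpyridin-3-yl in place of 2,4,6-trimethylpyridin-3-yl on the amide-type nitrogen the first exchange here to pass the scatter, whereas the earlier step did not: a 1.6-fold lower number from compound 1 to compound 2 (0.20 log units; within the scatter). The second comparison is less firm, as its floor stays within the scatter: an at least 1.4-fold higher number from compound 1 to compound 3 (0.16 log units; that floor lies within the scatter).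

From the compounds shown here alone, how far the true number of compound 3 lies past the limit remains open. Also open, going by these compounds, is whether an ethoxy or amino group in place of the methoxy group would stay close to compound 2 in this assay.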